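The source may report more compounds than this note shows. Statements on the series, on what has been measured and on what is new or still open speak of the compounds shown alone.

Measured in an ADME assay on a cell-free system (plasma, Homo sapiens) for metabolic stability, read by LC-MS; on this read-out higher numbers stand for a longer-lived compound and lower numbers for a shorter-lived compound:
- Compound 1 `NCc1ccc(C(=O)Nc2ccncc2F)cc1-c1cccc(C(=O)Oc2ccccc2)c1`: 0.117 h
- Compound 2 `NCc1ccc(C(=O)Nc2ccncc2F)cc1-c1cccc(C(=O)OCC2CC2)c1`: 0.3 h
- Compound 3 `NCc1ccc(C(=O)Nc2ccncc2F)cc1-c1cccc(C(=O)OCC2CCCO2)c1`: < 0.0834 h

Compound 3 gives no number, only a limit: it stands at the limit of < 0.0834 h in this assay, at which 1 of the 3 values shown sits. Its floor against compound 1 does not separate the two, as an at least 1.4-fold lower number from compound 1 to compound 3 (0.14 log units; that floor lies within the scatter) shows. Against compound 2 the gap is clear: an at least 3.5-fold lower number from compound 2 to compound 3 (0.55 log units; beyond the scatter).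

Compound 4 `CC(C)OCCOC(=O)c1cccc(-c2cc(C(=O)Nc3ccncc3F)ccc2CN)c1` has isopropoxymethyl in place of oxolan-2-yl, on a saturated chain carbon bound to an oxygen next to a carbonyl group (isopropoxymethyl in place of oxolan-2-yl on a saturated chain carbon bound to an oxygen next to a carbonyl group). The ring is gone, and the group enters at the same place.

Changes at this place have moved the half-life before, as in a 2.6-fold higher number from compound 1 to compound 2 (0.41 log units; beyond the scatter). The nearest measured neighbour is compound 3, and an at least 3.5-fold lower number from compound 2 to compound 3 (0.55 log units; beyond the scatter) is the step that bears most on the new group, so a short half-life is expected again. No step beyond the scatter is expected, and the estimated change is an at least 1.1-fold higher number from compound 3 to compound 4 (0.07 log units; that floor lies within the scatter). The assay may again report only a limit. For compound 4 the estimated half-life is 0.1 h, with an expected range of 0.05 h to 0.25 h.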

Compound 4, half-life: 0.1 h
For compound 4 middle estimate and measured number coincide at the digits printed; the measured number falls inside the stated range.
By their numbers in this assay, from the lowest: compounds 4 and 1 (each within the scatter of the next); then compound 2. At a limit, below all of these: compound 3.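

Compound 3 remains a limit and not a number: the limit of < 0.0834 h in this assay, at which 1 of the 4 values shown sits.
Swapping oxolan-2-yl for the ring-free isopropoxymethyl therefore gives only a floor (in this assay, an at least 1.1-fold higher number from compound 3 to compound 4 (0.07 log units; that floor lies within the scatter)), which does not separate the two groups. What is new is a true number for a chain that carries an oxygen at this place: the cyclopropyl group keeps its lead over a ring-free group as well (a 3.0-fold lower number from compound 2 to compound 4 (0.48 log units; beyond the scatter)), while 2-isopropoxyethyl cannot be told apart from phenyl (a 1.2-fold lower number from compound 1 to compound 4 (0.07 log units; within the scatter)).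

The compounds shown leave open whether a plain carbon chain such as pentyl, with no oxygen in it, would give a half-life closer to that of compound 2 or compound 4. They also leave open what an amine at the end of the chain would do to the half-life.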